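Replacing an aryl amide with a hydroxyalkyl amide

A few compounds are considered here, and "the series" means these few. Any claim that something is new, unique, unknown or untested is made for them only; others in the source may bear on it.

Measured in a functional assay on Caco-2 cells (Homo sapiens) for antiproliferative activity, read by MTT assay, with a stated time of 48 h; a higher number here means a weaker inhibitor, a lower number a stronger inhibitor:
- Compound 1 `CCn1c(C(=O)NCCN(C)C)ccc1C(CC)(CC)c1ccc(OCCC(O)(CC)CC)c(C)c1`: 1140 nM
- Compound 2 `CCn1c(C(=O)NCC#N)ccc1C(CC)(CC)c1ccc(OCCC(O)(CC)CC)c(C)c1`: > 50000 nM (a limit of the assay)
- Compound 3 `CCOc1ccc(NC(=O)c2ccc(C(CC)(CC)c3ccc(OCCC(O)(CC)CC)c(C)c3)n2CC)cc1`: > 50000 nM (a limit of the assay)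

Compound 3 gives only a limit, > 50000 nM, and not a number. Compound 4 `CCC(C)C(CO)NC(=O)c1ccc(C(CC)(CC)c2ccc(OCCC(O)(CC)CC)c(C)c2)n1CC` changes one group of compound 3: 1-(hydroxymethyl)-2-methylbutyl in place of 4-ethoxyphenyl on an amide-type nitrogen. In words, 1-(hydroxymethyl)-2-methylbutyl stands in place of 4-ethoxyphenyl on an amide-type nitrogen.

Within the data shown here, two measured steps bear on this change. Both take away the 2-(dimethylamino)ethyl group of compound 1, and both are large: an at least 43-fold higher number from compound 1 to compound 2 (1.64 log units; beyond the scatter) and an at least 43-fold higher number from compound 1 to compound 3 (1.64 log units; beyond the scatter). The third, a step that the two limits leave unreadable from compound 2 to compound 3, cannot be read, so it gives no guide to swapping one such group for another. Compound 4 also lacks the 2-(dimethylamino)ethyl group, so it is expected to stay far weaker than compound 1 in this assay. Only a small move toward a lower number is expected, and the expected step is an at least 1.6-fold lower number from compound 3 to compound 4 (0.22 log units; that floor lies within the scatter). The estimate for compound 4 is 30000 nM, with an expected range from 6000 nM to 50000 nM.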

Compound 4, half-maximal inhibitory concentration: > 50000 nM
Compound 4: a limit, no number; the forecaster's own chance of this, stated with the estimate: 60%; middle value at least 1.6-fold (0.22 log units) from the limit.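

Compound 4 gives only a limit of the assay, > 50000 nM, and not a number. Putting 1-(hydroxymethyl)-2-methylbutyl, an open chain with a hydrogen-bond donor, in place of the 2-(dimethylamino)ethyl group gives an at least 43-fold higher number from compound 1 to compound 4 (1.64 log units; beyond the scatter) in this assay, so neither dropping the aromatic ring of compound 3 nor adding this hydroxyl group brings a measurable value back. The steps among compound 2, compound 3 and compound 4 cannot be read, because all three rest on the same limit: the limit of > 50000 nM in this assay, at which 3 of the 4 values shown sit.

Going by these compounds, how the three compare with one another therefore stays open. Also open, on these data alone, is whether the value of compound 1 needs a dimethylamino group at the end of its chain, which a primary amine, a longer chain ending in dimethylamino or a carboxylic acid on this amide nitrogen could test.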